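Swapping 4-Chlorophenyl for 2-Methoxyphenyl: What to Expect

The source may report more compounds than this note shows. Statements on the series, on what has been measured and on what is new or still open speak of the compounds shown alone.

Compound 2 `CN(C)CCCCOc1ccccc1/C=C/c1ccc(Cl)cc1` gives the highest of the three measured numbers in a functional assay on the whole organism with Mus musculus as the target, at a dose of 50 mg/kg by the oral route (a higher number here means more inhibition at the dose given (going by the name of the read-out), a lower number less inhibition), at 62.5%. Compound 1 `CN(C)CCCCOc1ccccc1/C=C/c1ccccc1Cl` gives 50%, and compound 3 `CN(C)CCCCOc1ccccc1/C=C/c1ccccc1F` gives 17%. The untested compound 4 `COc1ccccc1/C=C/c1ccccc1OCCCCN(C)C` differs from compound 2 in one place: 2-methoxyphenyl in place of 4-chlorophenyl on a double-bonded chain carbon bound to a double-bonded chain carbon. Within the data shown here, no measured step involves a methoxy group, so the nearest guides are the two steps that exchange the 4-chlorophenyl of compound 2 for a 2-chlorophenyl or a 2-fluorophenyl: a number 12.5 percentage points higher from compound 1 to compound 2 (beyond the scatter) seen in reverse, and a number 45.5 percentage points lower from compound 2 to compound 3 (beyond the scatter). Both point to lower inhibition, so a drop of uncertain size is expected for compound 4, a number 30.5 percentage points lower from compound 2 to compound 4 (beyond the scatter). Compound 4 is estimated at 32%, with a range from 5% to 60%.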

Compound 4, a percentage reported as inhibition, in the whole organism at one dose (the size of the read-out at that dose, not a potency): 62.5%
Compound 4: the middle estimate sits 30.5 percentage points below what was measured, outside the stated range (above it).
By their numbers in this assay, from the lowest: compound 3; then compound 1; then compounds 2 and 4 (each within the scatter of the next).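

In this assay, 2-methoxyphenyl and 4-chlorophenyl cannot be told apart at this place (no change at the digits printed from compound 2 to compound 4 (within the scatter)), so a group other than 4-chlorophenyl can reach the same level. The group on the same aromatic carbon also matters: methoxy in place of chloro gives a number 12.5 percentage points higher from compound 1 to compound 4 (beyond the scatter), and methoxy in place of fluoro gives a number 45.5 percentage points higher from compound 3 to compound 4 (beyond the scatter). Nothing available explains these differences. Still open, as far as these compounds go, is how a 4-methoxyphenyl or a 2-hydroxyphenyl group would compare at this place, and whether a carboxylic acid on that ring would keep the inhibition.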